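Swapping a Cyclopentyl Amide for a Bulky Nitroxide Ring

This account rests on a few compounds, and the source may have more. Where it says the series, first, only, none or still open, it means among the compounds named here.

Of the compounds shown here, three measured so far share one core and differ only in the group carried by the benzylic amide. Compound 1 `Cc1noc(C)c1-c1nn(Cc2ccc(C(=O)N3CCCCC3)cc2)c(=O)c2ccccc12` gives 97300 nM in a functional assay on HepG2 cells (Homo sapiens) for antiproliferative activity, read by MTT assay, with a stated time of 72 h; a higher number here means a weaker inhibitor, a lower number a stronger inhibitor. Compound 2 `Cn1cc(-c2nn(Cc3ccc(C(=O)NC4CCCC4)cc3)c(=O)c3ccccc23)cn1` gives 84300 nM in this assay, the lowest of the two plain numbers, although its gap to compound 1 lies within the usual scatter. Compound 3 `Cc1noc(C)c1-c1nn(Cc2ccc(C(=O)NC3CCN(C)CC3)cc2)c(=O)c2ccccc12` reaches only the assay limit of > 100000 nM in this assay, which is a limit and not a number. Among the compounds with values here, the single step between measured neighbours is an at least 1.0-fold higher number from compound 1 to compound 3 (0.01 log units; that floor lies within the scatter), where a methylated piperidine attached through a nitrogen replaced a plain piperidine ring; the change reached (the limit of > 100000 nM in this assay, at which 1 of the 3 values shown sits).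

Compound 4 `Cn1cc(-c2nn(Cc3ccc(C(=O)NC4CC(C)(C)N([O])C(C)(C)C4)cc3)c(=O)c3ccccc23)cn1` is the next candidate. Compared with compound 2, (a group of 11 heavy atoms (9 carbon, 1 nitrogen, 1 oxygen; one six-membered non-aromatic ring with 1 hetero atom) in place of a group of 5 heavy atoms (5 carbon; one five-membered non-aromatic ring of carbon only), on an amide-type nitrogen). Like the step from compound 1 to compound 3, this adds a six-membered nitrogen-containing ring at the amide, and that earlier step brought no gain. So no step beyond the scatter is expected in this assay, with the outcome possibly ending at the limit again.

Compound 4 is therefore expected to give 95000 nM, within an estimated range from 35000 nM to 260000 nM. This estimate means a step of a 1.1-fold higher number from compound 2 to compound 4 (0.05 log units; within the scatter), expected to stay within the scatter.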

Compound 4, half-maximal inhibitory concentration: 27400 nM
Estimate against measurement, compound 4: 3.5-fold (0.54 log units) above; the whole stated range lies above it.
By their numbers in this assay, from the lowest: compound 4; then compounds 2 and 1 (each within the scatter of the next). At a limit, above all of these: compound 3.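

Within the data shown here, the amide-type nitrogen turns out to be a place where a change can register in this assay: putting the larger six-membered ring with its nitrogen and oxygen in place of cyclopentyl gives a 3.1-fold lower number from compound 2 to compound 4 (0.49 log units; beyond the scatter), the first step here that can be read as lying beyond the scatter. The step is modest and rests on a single pair of compounds, but it shows that a bulkier group with a hetero atom in its ring is tolerated on this amide in this assay, and that the number can go down as well as stay flat. Compound 3, with a different group on a related core, remains the only compound at a limit of the assay, which is not a number: the limit of > 100000 nM in this assay, at which 1 of the 4 values shown sits.

What the pair cannot tell is which part of the entering group carries the step, since the six-membered ring and the oxygen it holds change together. Also open, from the compounds shown here alone, is how an amine, a carboxylic acid or a longer chain would read in the same place on the amide-type nitrogen in this assay.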